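Cytotoxicity series: pyrrolidinyl in place of diethylamino

This account rests on a few compounds, and the source may have more. Where it says the series, first, only, none or still open, it means among the compounds named here.

Compound 1 `CCCCNC(=O)Nc1cc2nc(C3CCCCC3)[nH]c2cc1N(CC)CC` was run in an ADME assay on Vero cells (Chlorocebus sabaeus) for cytotoxicity, read by resazurin assay, with a stated time of 3 days; on this read-out lower numbers stand for stronger inhibition and higher numbers for weaker inhibition. In this assay compound 1 gives only a limit, > 100 ug/mL. Compound 2 `CCCOCC(=O)Nc1cc2nc(C3CCCCC3)[nH]c2cc1N(CC)CC` likewise gives only a limit in this assay, > 100 ug/mL. Compound 3 `CCOCCOC(=O)Nc1cc2nc(C3CCCCC3)[nH]c2cc1N(CC)CC` also reaches only a limit in this assay, > 100 ug/mL. The three exchanges on the carbonyl carbon therefore yield no readable steps: a step that the two limits leave unreadable from compound 1 to compound 2, a step that the two limits leave unreadable from compound 1 to compound 3 and a step that the two limits leave unreadable from compound 2 to compound 3. Compound 1 thus stands where the whole series stands, at the limit of > 100 ug/mL in this assay, at which 3 of the 3 values shown sit.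

Compound 4 `CCCCNC(=O)Nc1cc2nc(C3CCCCC3)[nH]c2cc1N1CCCC1` is not yet measured. It differs from compound 1 in one place (pyrrolidin-1-yl in place of diethylamino on an aromatic carbon). Among the measured compounds shown here, no measured step touches this position, and the measured steps on the carbonyl carbon are all unreadable, so they offer neither a size nor a direction. Compound 4 is expected to show no step beyond the scatter in this assay, a step that the limit leaves unreadable from compound 1 to compound 4. Compound 4 is therefore estimated at 150 ug/mL in this assay, within a range of 60 ug/mL to 400 ug/mL, and most probably it will again be reported as a limit rather than a number.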

Compound 4, half-maximal inhibitory concentration: > 100 ug/mL
Compound 4 was reported as a limit; the forecaster's own chance of this, stated with the estimate: 85%; the middle value lies beyond the limit too.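

Compound 1 and compound 4 both give only limits in this assay, so no step can be read for pyrrolidin-1-yl in place of diethylamino, and the series stays at one shared limit: the limit of > 100 ug/mL in this assay, at which 4 of the 4 values shown sit. The compounds shown leave open whether any exchange on the shared core gives a readable value in this assay.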